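A few compounds are considered here, and "the series" means these few. Any claim that something is new, unique, unknown or untested is made for them only; others in the source may bear on it.

Of the compounds shown here, two have so far been tested in a functional assay on the whole organism (strain albino) for inhibition, with Rattus norvegicus as the target, read by paw edema, with stated times of 30 min and 24 h, at a dose of 50 mg/kg by the oral route; on this read-out lower numbers stand for less inhibition and higher numbers for more inhibition at the one dose given (going by the name of the read-out). Compound 1 `Cc1ccc(-c2nn(-c3ccccc3)cc2/C=C/C(=O)CCC(=O)O)cc1` gives 3.79%, and compound 2 `NC(=O)c1ccccc1NC(=O)c1cn(-c2ccccc2)nc1-c1ccccc1` gives -3.79%; these two values lie within the usual scatter of each other, so neither compound is set apart from the other. Compound 3 `NC(=O)c1ccccc1NC(=O)c1cn(-c2ccccc2)nc1-c1ccc(Cl)cc1` has not yet been measured. It differs from compound 2 by chloro in place of hydrogen on an aromatic carbon. Among the measured compounds shown here, with no measured step between related compounds to lean on, the change expected from compound 2 to compound 3 is none beyond the scatter, namely a number 3.8 percentage points higher from compound 2 to compound 3 (within the scatter). Compound 3 is therefore estimated at 0%, within a range from -12% to 12%.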

Compound 3, a percentage reported as inhibition, in the whole organism at one dose (the size of the read-out at that dose, not a potency): 15.2%
Estimate against measurement, compound 3: 15.2 percentage points below; the measured number lies above the stated range.
By their numbers in this assay, from the lowest: compounds 2 and 1 (each within the scatter of the next); then compound 3.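

In this assay, among the compounds shown here, the change from phenyl to 4-chlorophenyl gives a number 19 percentage points higher from compound 2 to compound 3 (beyond the scatter), the first step that can be told apart from the scatter. This shows that the read-out can respond to a single added chlorine atom at this aromatic carbon, which compound 1 and compound 2 alone could not show. Nothing available here explains the step. This single pair leaves open whether chloro is unusual at this position or whether fluoro, methyl or methoxy would give a similar step.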